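A few compounds are considered here, and "the series" means these few. Any claim that something is new, unique, unknown or untested is made for them only; others in the source may bear on it.

Compound 1 `O=C(O)/C=C/c1ccc(Cn2ccnc2)cc1OCCc1ccc2ccccc2c1` and compound 2 `O=C(O)/C=C/c1ccc(Cc2ccccc2)cc1OCCc1ccc2ccccc2c1` share the same core and differ only in one group on a saturated chain carbon bound to an aromatic carbon. In an assay on CHO cells for displacement of a labelled ligand from prostaglandin E2 receptor EP2 subtype (Mus musculus), read by scintillation counting (a higher number here means a weaker inhibitor, a lower number a stronger inhibitor), compound 1 gives > 10000 nM, which is a limit of the assay and not a number. In this assay compound 2 likewise gives > 10000 nM, again only a limit of the assay. Because both values sit at the limit of > 10000 nM in this assay, at which 2 of the 2 values shown sit, the step that the two limits leave unreadable from compound 1 to compound 2 cannot be read in either direction. So compound 2 stands at the limit, with no measured value beyond it.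

Compound 3 `O=C(O)/C=C/c1ccc(COc2ccccc2)cc1OCCc1ccc2ccccc2c1` differs from compound 2 by phenoxy in place of phenyl on a saturated chain carbon bound to an aromatic carbon. Within the data shown here, the only measured step, from compound 1 to compound 2, is unreadable, so no measured step gives a size for this kind of change. Compound 3 is therefore expected to remain near the limit as well, with the step that the limit leaves unreadable from compound 2 to compound 3 expected to lie within the scatter. Compound 3 is estimated at 12000 nM, in a range from 2500 nM to 50000 nM, with a real chance that only a limit is reported.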

Compound 3, inhibition constant: 9200 nM
For compound 3 the middle estimate is 1.3-fold (0.12 log units) above the measured one, and the stated range covers the measured number.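

Compound 3 is the only compound shown that gives a number rather than a limit in this assay, at 9200 nM, so phenoxy at this place on a saturated chain carbon bound to an aromatic carbon brings a reading inside the range of the assay. Set against the two neighbouring compounds, this gives an at least 1.0-fold lower number from compound 2 to compound 3 (0.03 log units; that floor lies within the scatter) and an at least 1.0-fold lower number from compound 1 to compound 3 (0.03 log units; that floor lies within the scatter); each is only a floor, so the true steps could be larger, but what can be read so far does not go beyond ordinary scatter. The real size of both steps stays unknown because the compounds they start from give no number: the limit of > 10000 nM in this assay, at which 2 of the 3 values shown sit.

Still, the number for compound 3 is no evidence of strong binding, and the single extra oxygen atom in phenoxy cannot yet be credited with anything, since one compound cannot separate its effect from that of the slightly longer link. The compounds shown leave open whether an amine in place of that oxygen, a longer chain at this place, or a chlorine on the phenoxy ring would give a step clearly beyond the scatter.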